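Trimming an Isopropyl Group to Ethyl on Compound 2

The compounds below may be only part of what the source reports. "The series", "measured", "known", "first", "only" and "open" are said of these compounds alone.

Among the measured compounds shown here, in an ADME assay on microsomes from liver (Homo sapiens) for metabolic stability, read by LC-MS, with a stated time of 10 min (a higher number here means that more of the compound is left, a lower number that less of the compound is left), compound 2 `CC(C)N1CCN(c2cccc3c2C[C@H](CN(C)[C@H]2CCCc4cccnc42)NC3)CC1` gives 56.6%, the lowest of the three numbers measured so far. Compound 3 `CC(C)N(C[C@H]1Cc2c(cccc2N2CCNCC2)CN1)[C@H]1CCCc2cccnc21` gives 75% and compound 1 `c1cnc2c(c1)CCC[C@@H]2N(CC1CC1)C[C@H]1Cc2c(cccc2N2CCNCC2)CN1` gives 82.1%, and both lie beyond the usual scatter from compound 2.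

Compound 4 `CCN1CCN(c2cccc3c2C[C@H](CN(C)[C@H]2CCCc4cccnc42)NC3)CC1` has not yet been measured. It differs from compound 2 in one place: hydrogen in place of methyl on a saturated chain carbon bound to an amine nitrogen in a ring and a saturated chain carbon. Put simply, hydrogen stands in place of methyl on a saturated chain carbon bound to an amine nitrogen in a ring and a saturated chain carbon, which turns 4-isopropylpiperazin-1-yl into 4-ethylpiperazin-1-yl.

For the measured compounds named here, only one measured step also exchanges a small group, with isopropyl in place of cyclopropylmethyl on an amine nitrogen: a number 7.1 percentage points lower from compound 1 to compound 3 (within the scatter). Going by the values given here, that step involves a different pair of groups, and no measured compound carries the ethyl group, so it is only a loose guide. On this evidence, no change beyond the scatter is expected in this assay. The expected step is a number 1.4 percentage points higher from compound 2 to compound 4 (within the scatter), and this estimate carries real uncertainty. For compound 4 the estimated value is 58%, with an expected range of 44% to 72%.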

Compound 4, percent of the compound remaining: 0%
Compound 4: the middle estimate sits 58 percentage points above what was measured; the measured number lies below the stated range.
By their numbers in this assay, from the lowest: compound 4; then compound 2; then compounds 3 and 1 (each within the scatter of the next).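

Before this result, the only step between measured compounds was a number 7.1 percentage points lower from compound 1 to compound 3 (within the scatter), an exchange of small groups on a different amine nitrogen, and it gave no sign that so small an edit could matter much in this assay. Turning 4-isopropylpiperazin-1-yl into 4-ethylpiperazin-1-yl gives a number 56.6 percentage points lower from compound 2 to compound 4 (beyond the scatter), which shows that losing one methyl, a single carbon with no change in ring count, donors, acceptors or net charge, can by itself decide the outcome at this place in this pair. Nothing available accounts for such a large effect from such a small change.

What the compounds shown leave open is how narrow this effect is: a longer chain such as n-propyl, or a small ring such as cyclobutyl, on the same piperazine substituent would show whether ethyl stands alone or belongs to a wider trend. As far as these compounds go, it is also open whether the same edit would have so large an effect on a different version of the shared core, since this is a single pair.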